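This account rests on a few compounds, and the source may have more. Where it says the series, first, only, none or still open, it means among the compounds named here.

Measured compounds:
compound 1, `C=CC1=C(C(=O)NCCCCC)C(c2ccc(Cl)c(Cl)c2)OC1` — > 100000 nM
compound 2, `C=CC1=C(C(=O)NCc2ccccc2F)C(c2ccc(F)cc2)OC1` — > 100000 nM

Both compounds share one core and differ only in the groups attached to it. In a functional assay on HeLa cells (Homo sapiens) for cytotoxicity, read by MTT assay, with a stated time of 24 h (on this read-out lower numbers stand for stronger inhibition and higher numbers for weaker inhibition), compound 1 gives > 100000 nM. That value is a limit of the assay rather than a number. Compound 2 gives > 100000 nM in this assay, which is likewise a limit. For the measured compounds named here, compound 1 therefore stands exactly where every value so far stands, at the limit of > 100000 nM in this assay, at which 2 of the 2 values shown sit; no value here is an actual number.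

Compound 3, `C=CC1=C(C(=O)Nc2ccccc2OC)C(c2ccc(Cl)c(Cl)c2)OC1`, has not yet been tested. Compared with compound 1 the change is 2-methoxyphenyl in place of pentyl on an amide-type nitrogen. Going by the values given here, no measured pair here differs in one place, so there is no step to lean on. Because both values sit at the limit of > 100000 nM in this assay, at which 2 of the 2 values shown sit, the expectation is that this change produces no step beyond the usual scatter in this assay, and that compound 3 will again fall outside the range where a number can be read. The step this estimate means is a number no higher from compound 1 to compound 3 (the limit leaves the size open). Compound 3 is thus estimated at 100000 nM, with a range from 30000 nM to 300000 nM.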

Compound 3, half-maximal inhibitory concentration: > 100000 nM
Compound 3 gave a limit, no number; the forecaster's own chance of this, stated with the estimate: 80%; the middle value sits exactly at the limit.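

In this assay compound 3 gives > 100000 nM, which is a limit and not a number. No step between compound 1 and compound 3 can be read, because neither compound has a numerical value: the limit of > 100000 nM in this assay, at which 3 of the 3 values shown sit.

The compounds shown leave open whether any change to the groups on the shared core would give a readable number.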